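Amide substituent exchange on the shared core: next step

The source may report more compounds than this note shows. Statements on the series, on what has been measured and on what is new or still open speak of the compounds shown alone.

Measured in a functional assay on MCF7 cells (Homo sapiens) for inhibition, read by MTT assay, with a stated time of 48 h; a lower number here means a stronger inhibitor, a higher number a weaker inhibitor:
Compound 1 `COc1cc2cc(N)c(=O)oc2cc1OCCCOc1no[n+]([O-])c1S(=O)(=O)c1ccccc1` gives 2020 nM.
Compound 2 `COc1cc2cc(C(=O)Nc3ccccc3)c(=O)oc2cc1OCCCOc1no[n+]([O-])c1S(=O)(=O)c1ccccc1` gives 740 nM.

For the measured compounds named here, compound 2 holds the lower of the two numbers, the only step being a 2.7-fold lower number from compound 1 to compound 2 (0.44 log units; beyond the scatter), a modest gain. Compound 3 `COc1cc2cc(C(=O)NCc3ccccc3)c(=O)oc2cc1OCCCOc1no[n+]([O-])c1S(=O)(=O)c1ccccc1` differs from compound 2 by benzyl in place of phenyl on an amide-type nitrogen. Going by the values given here, the single step available touches the same amide position but exchanges amino for phenylcarbamoyl, so it bears only loosely here. For compound 3 the step is expected to stay within the scatter, a 1.2-fold higher number from compound 2 to compound 3 (0.09 log units; within the scatter). Compound 3 is estimated at 900 nM, between 350 nM and 2500 nM.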

Compound 3, half-maximal inhibitory concentration: 740 nM
The estimate for compound 3 lay 1.2-fold (0.09 log units) above the measured number; the range from low to high includes it.
By their numbers in this assay, from the lowest: compounds 2 and 3 (each within the scatter of the next); then compound 1.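

In this assay, benzyl in place of phenyl on the amide-type nitrogen leaves the two amides level (no change at the digits printed from compound 2 to compound 3 (within the scatter)), so this exchange does not separate them. The gain over the amino group is kept with benzylcarbamoyl as well (a 2.7-fold lower number from compound 1 to compound 3 (0.44 log units; beyond the scatter)), so it is not confined to phenylcarbamoyl. Nothing available explains why the two amides read alike.

Still open, on these data alone, is whether a longer chain, such as phenethyl on the same nitrogen, keeps this level. A carboxylic acid or a dimethylamino group on the benzyl ring is equally untested by the compounds shown.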